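Adding a Hydroxyl to the Aromatic Arm of Compound 1

This account rests on a few compounds, and the source may have more. Where it says the series, first, only, none or still open, it means among the compounds named here.

Compound 1 `COc1ccccc1CNc1ncnc2c1ncn2[C@@H]1O[C@H](CO)[C@@H](O)[C@H]1O` was tested in a functional assay on B16 cells (Mus musculus) for antiproliferative activity, with a stated time of 72 h; a lower number here means a stronger inhibitor, a higher number a weaker inhibitor. In this assay compound 1 gives only a limit, > 166000 nM, not a number. Compound 2 `OC[C@H]1O[C@@H](n2cnc3c(NCc4cc(F)cc(F)c4)ncnc32)C(O)C1O` is a close relative; in this assay compound 2 likewise gives only a limit, > 166000 nM. Both sit at the limit of > 166000 nM in this assay, at which 2 of the 2 values shown sit, so compound 1 stands at the edge of what the assay can see. Compound 3 `COc1cccc(CNc2ncnc3c2ncn3[C@@H]2O[C@H](CO)[C@@H](O)[C@H]2O)c1O` carries 2-hydroxy-3-methoxyphenyl in place of 2-methoxyphenyl on a saturated chain carbon bound to a nitrogen on an aromatic ring. Within the data shown here, with no measured step to lean on, the expected step is a step that the limit leaves unreadable from compound 1 to compound 3, none beyond the scatter. Compound 3 is expected to give about 200000 nM, between 50000 nM and 800000 nM, most likely again as a limit.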

Compound 3, half-maximal inhibitory concentration: > 166000 nM
Compound 3: no number, only a limit; the forecaster's own chance of this, stated with the estimate: 85%; the middle value is on the limit's open side.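

Among these compounds, compound 1 and compound 3 each give only a limit in this assay, and no step between them can be read. The compounds shown leave open whether 2-hydroxy-3-methoxyphenyl in place of 2-methoxyphenyl changes activity at all.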